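Notes on the dichlorobenzyl ether step in this series

The source may report more compounds than this note shows. Statements on the series, on what has been measured and on what is new or still open speak of the compounds shown alone.

Measured so far:
compound 1 `Cc1ccc(NC(=O)NC(=O)c2ccc(OCc3ccc(C(F)(F)F)cc3)cc2)cc1-c1nc2ccccc2[nH]1` — 15300 nM
compound 2 `Cc1ccc(NC(=O)NC(=O)c2ccc(OCc3cccc(Cl)c3Cl)cc2)cc1-c1nc2ccccc2[nH]1` — 42100 nM

In a functional assay on SW-620 cells (Homo sapiens) for inhibition, read by MTT assay, with a stated time of 48 h (on this read-out lower numbers stand for stronger inhibition and higher numbers for weaker inhibition), compound 2 gives 42100 nM, the higher of the two numbers. Compound 1 gives 15300 nM. Among the measured compounds shown here, the only measured step, a 2.8-fold higher number from compound 1 to compound 2 (0.44 log units; beyond the scatter), concerns a different exchange of the whole aryl group and does not bear directly on the next change. Compound 3 `Cc1ccc(NC(=O)NC(=O)c2ccc(OCc3ccc(Cl)cc3Cl)cc2)cc1-c1nc2ccccc2[nH]1` differs from compound 2 by 2,4-dichlorophenyl in place of 2,3-dichlorophenyl on a saturated chain carbon bound to an oxygen on an aromatic ring. For the measured compounds named here, with no step of this kind measured, the change from compound 2 to compound 3 in this assay is expected to stay within the scatter, a 1.2-fold lower number from compound 2 to compound 3 (0.08 log units; within the scatter). For compound 3 the estimate is 35000 nM, with a range from 12000 nM to 100000 nM.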

Compound 3, half-maximal inhibitory concentration: 12200 nM
Compound 3: the middle estimate sits 2.9-fold (0.46 log units) above what was measured; the measured number falls inside the stated range.
By their numbers in this assay, from the lowest: compounds 3 and 1 (each within the scatter of the next); then compound 2.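

In this assay, rearranging the same atoms matters at this position: 2,4-dichlorophenyl in place of 2,3-dichlorophenyl gives a 3.5-fold lower number from compound 2 to compound 3 (0.54 log units; beyond the scatter) on the saturated chain carbon bound to the oxygen. 2,4-Dichlorophenyl in place of 4-(trifluoromethyl)phenyl gives a 1.3-fold lower number from compound 1 to compound 3 (0.10 log units; within the scatter) and so does not separate these two groups, leaving compound 2 alone apart from the other two. Nothing at hand accounts for the gap between the two dichlorophenyl groups.

Open, from the compounds shown here alone, is whether a chlorophenyl, fluorophenyl or methoxyphenyl group would follow compound 3 or compound 2 here. Also open, going by these compounds, is whether an amine in place of the ether oxygen would preserve the difference.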